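Swapping Bromo for Fluoro on a Fused Aromatic Core

The source may hold more compounds than are shown below. What is called first, only, known or untested is meant among the compounds shown, and "the series" means these compounds.

Compound 1 `O=C(CCCCCCNC(=O)C(O)(O)C(F)(F)F)Nc1nc2ccc(Br)cc2s1` is tested in a functional assay on HCT-116 cells (Homo sapiens) for inhibition, read by colorimetric assay, with a stated time of 3 days (on this read-out lower numbers stand for stronger inhibition and higher numbers for weaker inhibition), and gives 10300 nM. Compound 2 `O=C(CCCCCCNC(=O)C(O)(O)C(F)(F)F)Nc1ccc(F)cc1`, which carries a simpler aromatic amide end, gives 7570 nM in this assay, and the two numbers sit within the usual scatter of each other. Compound 3 `O=C(CCCCCCC(O)C(F)(F)F)Nc1ccccc1` is reported in this assay only as a limit, > 40000 nM, and not as a number (the limit of > 40000 nM in this assay, at which 1 of the 3 values shown sits). Compound 4 `O=C(CCCCCCNC(=O)C(O)(O)C(F)(F)F)Nc1nc2ccc(F)cc2s1` differs from compound 1 in one place: fluoro in place of bromo on an aromatic carbon. Going by the values given here, no measured pair in this set shows the same change, so its size is unknown here. The step from compound 1 to compound 4 in this assay is expected to stay within the scatter, a 1.2-fold higher number from compound 1 to compound 4 (0.07 log units; within the scatter). Compound 4 is therefore estimated at 12000 nM, with a likely range from 5000 nM to 30000 nM.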

Compound 4, half-maximal inhibitory concentration: 6470 nM
Beside the measured number, compound 4's estimate is 1.9-fold (0.27 log units) above it, and the stated range covers the measured number.
By their numbers in this assay, from the lowest: compounds 4, 2 and 1 (each within the scatter of the next). At a limit, above all of these: compound 3.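

In this assay, fluoro in place of bromo on an aromatic carbon of the shared core gives a 1.6-fold lower number from compound 1 to compound 4 (0.20 log units; within the scatter), so the read-out does not separate these two halogens at this position. Going by these compounds alone, this is the first pair in the set that differs in one place only, and the earlier compounds could not show the size of this change on its own. From the compounds shown here alone, whether an amine or a methoxy group at this position would also leave the number within the scatter stays open. Nothing measured here bears on why this step is so small.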